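Taking one sulfanyl group off compound 2

The source may hold more compounds than are shown below. What is called first, only, known or untested is meant among the compounds shown, and "the series" means these compounds.

In a physicochemical assay for pharmacokinetics, at 37 degrees C (a lower number here means that the compound disappears faster, a higher number that the compound lasts longer), compound 2 (`CO[C@H]1C(=O)N2C(C(=O)c3ccccc3)=C(CSc3nnnn3C)C(Sc3nnnn3C)S(=O)(=O)[C@H]12`) gives 850 h and stands highest of the two measured compounds, while compound 1 (`CO[C@H]1C(=O)N2C(C(=O)c3ccccc3)=C(C)C(Sc3nnnn3C)S(=O)(=O)[C@H]12`) gives 120 h and stands lower. Compound 3 (`CO[C@H]1C(=O)N2C(C(=O)c3ccccc3)=C(CSc3nnnn3C)CS(=O)(=O)[C@H]12`) has hydrogen in place of (1-methyl-1H-tetrazol-5-yl)sulfanyl on a saturated ring carbon next to the ring sulfur (hydrogen in place of (1-methyl-1H-tetrazol-5-yl)sulfanyl on a saturated ring carbon). Going by the values given here, the only related measurement is the same group entering on a saturated chain carbon instead, which gave a 7.1-fold higher number from compound 1 to compound 2 (0.85 log units; beyond the scatter) as a modest step beyond the scatter. That place differs, so its reverse is only a rough guide. A drop in this assay of similar or smaller size is expected, estimated as a 4.3-fold lower number from compound 2 to compound 3 (0.63 log units; beyond the scatter) with wide uncertainty. For compound 3 the expected half-life is 200 h (from 40 h to 1000 h).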

Compound 3, half-life: 8.6 h
For compound 3 the middle estimate is 23-fold (1.37 log units) above the measured one; the whole stated range lies above it.
By their numbers in this assay, from the lowest: compound 3; then compound 1; then compound 2.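

Removing the (1-methyl-1H-tetrazol-5-yl)sulfanyl group from the saturated ring carbon next to the ring sulfur gives, in this assay, a 99-fold lower number from compound 2 to compound 3 (1.99 log units; beyond the scatter), a large step. The same group on the saturated chain carbon gave only a modest step, a 7.1-fold higher number from compound 1 to compound 2 (0.85 log units; beyond the scatter), so in this pair of changes the ring carbon is the place where the group counts for more. No measurement here explains this. Still open, as far as these compounds go, is whether this ring carbon needs this particular group, or whether a methylsulfanyl group or an amine there would keep the half-life long.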